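The compounds below may be only part of what the source reports. "The series", "measured", "known", "first", "only" and "open" are said of these compounds alone.

Compound 1 `CCN(CC)CCNC(=O)c1ccc(C(CC)(CC)c2ccc(OCCC(O)(CC)CC)c(C)c2)n1CC` gives 550 nM.
Compound 2 `CCn1c(C(=O)N(C)CC(=O)O)ccc1C(CC)(CC)c1ccc(OCCC(O)(CC)CC)c(C)c1` gives 79 nM.
Compound 3 `CCn1c(C(=O)NC(CC(=O)O)C(=O)OC)ccc1C(CC)(CC)c1ccc(OCCC(O)(CC)CC)c(C)c1` gives 10200 nM.

In a functional assay on MCF7 cells (Homo sapiens) for antiproliferative activity, read by MTT assay, with a stated time of 48 h (a higher number here means a weaker inhibitor, a lower number a stronger inhibitor), compound 1 stands second highest of the three numbers: the nearer neighbour is reached by a 7.0-fold lower number from compound 1 to compound 2 (0.84 log units; beyond the scatter), the farther one by a 19-fold higher number from compound 1 to compound 3 (1.27 log units; beyond the scatter). Compound 4 `CCn1c(C(=O)NC(CO)CCO)ccc1C(CC)(CC)c1ccc(OCCC(O)(CC)CC)c(C)c1` has not yet been measured. The change from compound 1 is 3-hydroxy-1-(hydroxymethyl)propyl in place of 2-(diethylamino)ethyl on an amide-type nitrogen. The two measured steps both replace the group on the same amide-type nitrogen, so both bear on this change, but they point in opposite directions: a small acid-bearing group brought a 7.0-fold lower number from compound 1 to compound 2 (0.84 log units; beyond the scatter), whereas a larger acid-and-ester group brought a 19-fold higher number from compound 1 to compound 3 (1.27 log units; beyond the scatter). Within the data shown here, neither step introduces the 3-hydroxy-1-(hydroxymethyl)propyl group, which carries no net charge and has two hydrogen-bond donors, so no measured step matches it closely. Given that one step improved and the other weakened the number, and that the new group differs from both, the expected outcome for compound 4 is a step in the weaker direction of modest size, a 2.7-fold higher number from compound 1 to compound 4 (0.44 log units; beyond the scatter), with wide uncertainty. The estimate for compound 4 in this assay is 1500 nM, with a range from 300 nM to 8000 nM.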

Compound 4, half-maximal inhibitory concentration: 31400 nM
Compound 4: middle estimate off by 21-fold (1.32 log units), on the low side, outside the stated range (above it).
By their numbers in this assay, from the lowest: compound 2; then compound 1; then compound 3; then compound 4.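

In this assay, putting 3-hydroxy-1-(hydroxymethyl)propyl in place of 2-(diethylamino)ethyl on this amide-type nitrogen gives a 57-fold higher number from compound 1 to compound 4 (1.76 log units; beyond the scatter), so a neutral group bearing hydroxyl groups did not retain the activity of compound 1 at this position. The same group also gives a 3.1-fold higher number from compound 3 to compound 4 (0.49 log units; beyond the scatter), which means that the two branched groups in this set, the hydroxyl-bearing one and the one carrying an acid and an ester, both sit at the weak end, while the unbranched groups of compound 1 and compound 2 sit at the strong end. Among these compounds, the change at this single position now spans a 400-fold higher number from compound 2 to compound 4 (2.60 log units; beyond the scatter), showing that the group on this nitrogen can shift the number far more than the earlier compounds revealed.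

No measurement available here explains why these groups differ so widely. From the compounds shown here alone, it remains open whether branching or the particular atoms in the group matter more, and an unbranched 2-hydroxyethyl chain or a simple carboxymethyl group on an amide nitrogen that keeps its hydrogen would help to separate the two.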